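A few compounds are considered here, and "the series" means these few. Any claim that something is new, unique, unknown or untested is made for them only; others in the source may bear on it.

Of the compounds shown here, three have been measured in an ADME assay on microsomes from liver (Mus musculus, strain CD1) for metabolic stability, read by LC-MS, using NADPH, with a stated time of 60 min; a lower number here means that the compound disappears faster, a higher number that the compound lasts longer. Compound 1 `N=c1c2c(-c3ccccc3)c(-c3ccccc3)n(Cc3ccccc3)c2ncn1CCNc1ccncc1` gives 0.498 h, compound 2 `Cc1c(C)n(Cc2ccccc2)c2ncn(C3CCOCC3)c(=N)c12` gives 0.448 h, and compound 3 `COc1ccc(Cn2c(-c3ccccc3)c(-c3ccccc3)c3c(=N)n(CC4CCOCC4)cnc32)cc1` gives 0.217 h, the lowest of the three numbers; its distance to each of the other two lies beyond the usual scatter of repeated measurements, so compound 3 is the one that disappears fastest among these three.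

Compound 4 `COc1ccc(Cn2c(-c3ccccc3)c(-c3ccccc3)c3c(=N)n(CCCO)cnc32)cc1` has not yet been measured. It differs from compound 3 in one place: 2-hydroxyethyl in place of oxan-4-yl on a saturated chain carbon bound to an aromatic nitrogen. Within the data shown here, no pair of measured compounds that differ in a single place is available, so nothing among the three measured compounds shows what a swap of this kind does in this assay. In the absence of such a comparison, only a small step is expected for compound 4, upward in direction but not clearly beyond the usual scatter. For compound 4 the expected step is a 1.4-fold higher number from compound 3 to compound 4 (0.14 log units; within the scatter). Compound 4 is estimated to reach 0.3 h, with a range from 0.13 h to 0.7 h.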

Compound 4, half-life: 0.332 h
Compound 4: the middle estimate sits 1.1-fold (0.04 log units) below what was measured, and the stated range covers the measured number.
By their numbers in this assay, from the lowest: compounds 3, 4, 2 and 1 (each within the scatter of the next, the first and the last beyond it).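

Among these compounds, this is the first comparison here that isolates one place: in this assay, 2-hydroxyethyl in place of oxan-4-yl on a saturated chain carbon bound to an aromatic nitrogen gives a 1.5-fold higher number from compound 3 to compound 4 (0.18 log units; within the scatter) and so stays within the usual scatter. The change removes the ring, shortens the group and brings in a hydrogen-bond donor, yet for this pair the two half-lives cannot be told apart from repeat measurements. No available evidence bears on why the step has this size.

On these data alone, whether a longer chain, or an amine or a carboxylic acid at the end of the chain, would give a step beyond the scatter remains open. Also open, as far as these compounds go, is whether the same swap would read alike on a core carrying other groups.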